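A few compounds are considered here, and "the series" means these few. Any claim that something is new, unique, unknown or untested is made for them only; others in the source may bear on it.

Compound 1 `COc1cc(/C=C/C(=O)/C=C(/C=C/c2ccc(O)c(OC)c2)NCCCO)ccc1O`: 88500 nM
Compound 2 `COCCNC(=C\C(=O)/C=C/c1ccc(O)c(OC)c1)/C=C/c1ccc(O)c(OC)c1`: 63000 nM

Both values come from a toxicity assay on CHO-K1 cells (Cricetulus griseus) for cytotoxicity, read by MTT assay, with a stated time of 48 h; on this read-out higher numbers stand for weaker inhibition and lower numbers for stronger inhibition. Going by the values given here, compound 2 lies within the scatter of compound 1, the only other compound measured, so the two cannot be ranked. Compound 3 `COCCCNC(=C\C(=O)/C=C/c1ccc(O)c(OC)c1)/C=C/c1ccc(O)c(OC)c1` differs from compound 2 by a single change: methoxymethyl in place of methoxy on a saturated chain carbon, two bonds along the chain from an amine nitrogen. Methoxymethyl stands in place of methoxy on a saturated chain carbon, two bonds along the chain from an amine nitrogen, so (2-methoxyethyl)amino becomes (3-methoxypropyl)amino. Among the compounds with values here, one measured step bears on this place: a 1.4-fold lower number from compound 1 to compound 2 (0.15 log units; within the scatter). Within the data shown here, with that step the only guide, and itself within the scatter, no step beyond the scatter is expected in this assay, in either direction. The expected step is a 1.1-fold higher number from compound 2 to compound 3 (0.05 log units; within the scatter). The estimate for compound 3 is 70000 nM, with an expected range of 35000 nM to 130000 nM.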

Compound 3, half-maximal inhibitory concentration: 53700 nM
Compound 3: the middle estimate sits 1.3-fold (0.12 log units) above what was measured, and the stated range covers the measured number.
By their numbers in this assay, from the lowest: compounds 3, 2 and 1 (each within the scatter of the next).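

In this assay, the change from (2-methoxyethyl)amino to (3-methoxypropyl)amino gives a 1.2-fold lower number from compound 2 to compound 3 (0.07 log units; within the scatter) and so adds a second change at this chain position that cannot be told from the scatter. The pair of compounds 1 and 3 adds a different comparison, methyl in place of hydrogen on an oxygen on a saturated carbon, which gives a 1.6-fold lower number from compound 1 to compound 3 (0.22 log units; within the scatter) and also stays inside the scatter. Across these three compounds, then, neither change at the chain end separates one compound from another in this read-out, and nothing available bears on why these steps are so small. The compounds shown leave open whether an amine, a carboxylic acid or a much longer chain at this place would give a step beyond the scatter. They also leave open whether a ring there would do so.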